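The compounds below may be only part of what the source reports. "The series", "measured", "known", "first", "only" and "open" are said of these compounds alone.

Going by the values given here, compound 1 `CCN(c1ccc(C#N)c(Cl)c1)c1cc(-n2cnc3ccccc32)ccc1C` is the only member of this small set with a numerical result: in a functional assay on VCaP cells (Homo sapiens) for antiproliferative activity, read by CCK-8 assay, with a stated time of 6 days (a lower number here means a stronger inhibitor, a higher number a weaker inhibitor), compound 1 gives 8560 nM. Compound 2 `CCN(c1cccc(-n2ccnc2)c1)c1ccc(C#N)c(Cl)c1` is reported only as a limit of the assay, > 30000 nM, and so stands as the limit of > 30000 nM in this assay, at which 1 of the 2 values shown sits. Among the compounds with values here, the two compounds differ in more than one place, so their values cannot be read as a single step; they show only that compound 1 has a measurable number where compound 2 does not.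

Compound 3 `CCN(c1ccc(C#N)c(Cl)c1)c1cc(-c2ccoc2)ccc1C` is the unmeasured analogue of compound 1. The change is furan-3-yl in place of 1H-benzimidazol-1-yl on an aromatic carbon, a single ring with one hetero atom taking the place of the fused pair of rings. With compound 1 already weak, the step of a 1.8-fold higher number from compound 1 to compound 3 (0.24 log units; within the scatter) is expected to run toward weaker inhibition, possibly past the scatter. In this assay compound 3 is therefore expected to give about 15000 nM, within a range of 5000 nM to 30000 nM.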

Compound 3, half-maximal inhibitory concentration: 4010 nM
The estimate for compound 3 lay 3.7-fold (0.57 log units) above the measured number, outside the stated range (below it).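

At the aromatic carbon para to a methyl group, the fused pair of rings of compound 1 is not required for a measurable result in this assay: furan-3-yl in place of 1H-benzimidazol-1-yl gives a 2.1-fold lower number from compound 1 to compound 3 (0.33 log units; beyond the scatter). This single step is beyond the scatter and modest, and it shows that a single five-membered ring with fewer heavy atoms and no nitrogen can stand at this position without loss of activity. Nothing shown here accounts for the direction of this step.

The compounds shown leave open whether the lower number follows from losing the six-membered ring or from oxygen taking the place of the nitrogens. As far as these compounds go, how a pyridine ring, a primary amine or a carboxylic acid would read at this carbon also stays open.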